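Ring change at the aromatic oxygen: estimate for compound 3

This account rests on a few compounds, and the source may have more. Where it says the series, first, only, none or still open, it means among the compounds named here.

Compound 1 `CCCCCOc1cccc2ccc(N)nc12` gives 580 nM in an assay on cells with melanin-concentrating hormone receptor 1 (Homo sapiens) as the target, read by radioligand binding; a lower number here means a stronger inhibitor, a higher number a weaker inhibitor. Among the measured compounds shown here, compound 2 `Nc1ccc2cccc(OCCC3CC3)c2n1` gives 492 nM in this assay; compound 1 is its only comparison, and the step of a 1.2-fold lower number from compound 1 to compound 2 (0.07 log units; within the scatter) stays within the scatter. Compound 3 `CC1CCC(Oc2cccc3ccc(N)nc23)C1` carries 3-methylcyclopentyl in place of 2-cyclopropylethyl on an oxygen on an aromatic ring. For the measured compounds named here, the single measured step that bears on this kind of change, a 1.2-fold lower number from compound 1 to compound 2 (0.07 log units; within the scatter), was small, so the expected step is a 1.0-fold higher number from compound 2 to compound 3 (0.01 log units; within the scatter), nothing beyond the scatter. Compound 3 is therefore estimated at 500 nM in this assay, with a range from 200 nM to 1300 nM.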

Compound 3, half-maximal inhibitory concentration: 823 nM
Beside the measured number, compound 3's estimate is 1.6-fold (0.22 log units) below it; the measured number falls inside the stated range.
By their numbers in this assay, from the lowest: compounds 2, 1 and 3 (each within the scatter of the next).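

In this assay, 3-methylcyclopentyl on an oxygen on an aromatic ring reads like the open-chain groups, with a 1.7-fold higher number from compound 2 to compound 3 (0.22 log units; within the scatter) and a 1.4-fold higher number from compound 1 to compound 3 (0.15 log units; within the scatter) both within the scatter. This position therefore accepts a five-membered non-aromatic ring of carbon only, as well as pentyl and 2-cyclopropylethyl, with no step beyond the scatter so far. No measurement on hand bears on the reason for this result. On these data alone, all three groups contain carbon only, so the effect of an amine or a carboxylic acid at this oxygen remains open. Plain cyclopentyl, without the methyl, and a longer chain also remain open.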